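A Methoxy Group Moves to a New Ring Position

A few compounds are considered here, and "the series" means these few. Any claim that something is new, unique, unknown or untested is made for them only; others in the source may bear on it.

Compound 1 `O=C1C(Nc2ccccc2)=CC(=O)c2c1nc1n2[C@H]2OC[C@@H](O)[C@H]2OC1` gives 3560 nM in a functional assay on ECa-109 cells for inhibition, with ECa-109 cell line (Homo sapiens) as the target, read by sulforhodamine B assay; a higher number here means a weaker inhibitor, a lower number a stronger inhibitor.
Compound 2 `CCc1ccc(NC2=CC(=O)c3nc4n(c3C2=O)[C@H]2OC[C@@H](O)[C@H]2OC4)cc1` gives 3080 nM.
Compound 3 `COc1ccccc1NC1=CC(=O)c2nc3n(c2C1=O)[C@H]1OC[C@@H](O)[C@H]1OC3` gives > 4000 nM, a limit of the assay rather than a number.

Within the data shown here, compound 1 and compound 2 sit within the scatter of each other, and the third value is a limit, so no compound stands out among the three. Compound 4 `COc1cccc(NC2=CC(=O)c3c(nc4n3[C@H]3OC[C@@H](O)[C@H]3OC4)C2=O)c1` differs from compound 1 by methoxy in place of hydrogen on an aromatic carbon. Among the measured compounds shown here, the only measured step involving a methoxy group is an at least 1.2-fold higher number from compound 2 to compound 3 (0.11 log units; that floor lies within the scatter). Compound 3 sits at the limit of > 4000 nM in this assay, at which 1 of the 3 values shown sits. That step points, if anywhere, toward a weaker inhibitor, but its size is known only by its floor. For compound 4 a step of about a 1.1-fold higher number from compound 1 to compound 4 (0.05 log units; within the scatter) is therefore expected, within the scatter. Compound 4 is estimated at 4000 nM, with a range from 2000 nM to 8000 nM, and a real chance that only a limit is reported.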

Compound 4, half-maximal inhibitory concentration: 3340 nM
For compound 4 the middle estimate is 1.2-fold (0.08 log units) above the measured one, and the stated range covers the measured number.
By their numbers in this assay, from the lowest: compounds 2, 4 and 1 (each within the scatter of the next). At a limit, above all of these: compound 3.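

Putting 3-methoxyphenyl in place of phenyl gives a 1.1-fold lower number from compound 1 to compound 4 (0.03 log units; within the scatter), so in this assay a methoxy group at this position of the ring makes no difference beyond the scatter. Unlike the earlier methoxy comparison, this one rests on two real numbers. Compound 3 also carries a methoxy group, but its value is a limit, not a number: the limit of > 4000 nM in this assay, at which 1 of the 4 values shown sits.

From the compounds shown here alone, whether an amine, a carboxylic acid or a longer chain at this position would move the number beyond the scatter remains open. Going by these compounds, the actual value of compound 3 also remains open.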